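This account rests on a few compounds, and the source may have more. Where it says the series, first, only, none or still open, it means among the compounds named here.

Measured compounds:
Compound 1, `Clc1ccc(-c2nc(N3CCCCC3)c3nc[nH]c3n2)cc1Cl`; in an assay on cells for displacement of a labelled ligand from adenosine receptor A2b (Homo sapiens), read by scintillation counting and radioligand binding, with a stated time of 30 min, tested at 10 uM (a higher number here means more inhibition at the concentration tested (going by the name of the read-out), a lower number less inhibition), compound 1 gives 0.7%.
Compound 2, `Clc1ccc(Cl)c(-c2nc(N3CCCCC3)c3nc[nH]c3n2)c1`; in this assay compound 2 gives 12.1%.

Compound 2 stands highest of the two numbers, and its nearest neighbour, compound 1, lies lower by a gap that is beyond the usual scatter. Both numbers nonetheless sit at the low end of the scale. Compound 3, `Clc1cccc(-c2nc(N3CCCCC3)c3nc[nH]c3n2)c1`, differs from compound 2 in one place: hydrogen in place of chloro on an aromatic carbon. For the measured compounds named here, no step between two measured compounds is known here, so there is nothing that directly shows what this change does. In this assay the step of a number 6.1 percentage points lower from compound 2 to compound 3 (within the scatter) is expected to be small and downward, or none beyond the scatter, since compound 2 itself starts from a low reading. For compound 3 the estimate in this assay is 6%, with a range from -4% to 18%.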

Compound 3, a percentage reported as inhibition, at one concentration (the size of the read-out at that concentration, not a potency): > 80%
Compound 3 ended at the assay's limit (the forecaster's own chance of this, stated with the estimate: 3%); middle value at least 74 percentage points away from the limit.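

In this assay, hydrogen in place of chloro on an aromatic carbon, ortho to a large group and para to a chloro group, proves to be a large change, with a number at least 67.9 percentage points higher from compound 2 to compound 3 (beyond the scatter). The same kind of exchange starting from the other dichloro compound gives a number at least 79.3 percentage points higher from compound 1 to compound 3 (beyond the scatter), so both low readings give way to a high one once the ring carries a single chloro, which the two dichloro compounds alone could not show. Compound 3 stands at a limit of the assay, not at a number: the limit of > 80% in this assay, at which 1 of the 3 values shown sits.

As far as these compounds go, how far compound 3 lies past that limit stays open, and with it the full size of both steps. Also open, from the compounds shown here alone, is whether a fluoro, a methoxy group or an amine in place of the remaining chloro would hold the reading of compound 3.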